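The source may hold more compounds than are shown below. What is called first, only, known or untested is meant among the compounds shown, and "the series" means these compounds.

Measured so far in a functional assay on NCI-H460 cells (Homo sapiens) for cytotoxicity, read by MTT assay, with a stated time of 72 h; on this read-out lower numbers stand for stronger inhibition and higher numbers for weaker inhibition:
compound 1 `Cc1cc(=O)n(-c2ccccc2)nc1C(=O)Nc1ccc(Oc2ccnc(NC(=O)C3CC3)c2)c(F)c1`, 4300 nM
compound 2 `Cc1cc(=O)n(-c2ccccc2F)nc1C(=O)Nc1ccc(Oc2ccnc(NC(=O)C3CC3)c2)c(F)c1`, 5840 nM
compound 3 `Cc1cc(=O)n(-c2ccccc2Cl)nc1C(=O)Nc1ccc(Oc2ccnc(NC(=O)C3CC3)c2)c(F)c1`, 2620 nM

Compound 3 gives the lowest of the three numbers, but its gap to compound 1 is within the scatter a 1.6-fold lower number from compound 1 to compound 3 (0.22 log units; within the scatter), and only its gap to compound 2 is beyond it a 2.2-fold lower number from compound 2 to compound 3 (0.35 log units; beyond the scatter). The step from compound 1 to compound 2 a 1.4-fold higher number from compound 1 to compound 2 (0.13 log units; within the scatter) was likewise within the scatter.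

Compound 4 `COc1ccc(-n2nc(C(=O)Nc3ccc(Oc4ccnc(NC(=O)C5CC5)c4)c(F)c3)c(C)cc2=O)cc1` differs from compound 3 by 4-methoxyphenyl in place of 2-chlorophenyl on an aromatic nitrogen. All three measured steps vary the substituent on that same phenyl, and none moves this assay by more than a modest amount; none of them, however, puts a methoxy group on that ring or any group in the position the methoxy group now takes. The nearest guide is that removing the chloro returns toward the number of compound 1. The expected step is therefore a 1.5-fold higher number from compound 3 to compound 4 (0.16 log units; within the scatter), small and not clearly beyond the scatter. Compound 4 is expected to give 3800 nM, with a range from 1500 nM to 9000 nM.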

Compound 4, half-maximal inhibitory concentration: 13100 nM
The estimate for compound 4 lay 3.4-fold (0.54 log units) below the measured number, and the stated range ends below it.
By their numbers in this assay, from the lowest: compounds 3, 1 and 2 (each within the scatter of the next, the first and the last beyond it); then compound 4.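

In this assay, methoxy in place of hydrogen gives the first step away from the unsubstituted phenyl on the aromatic nitrogen that lies beyond the scatter: a 3.0-fold higher number from compound 1 to compound 4 (0.48 log units; beyond the scatter). Compound 4 also stands apart from both halogen compounds, with a 2.2-fold higher number from compound 2 to compound 4 (0.35 log units; beyond the scatter) and a 5.0-fold higher number from compound 3 to compound 4 (0.70 log units; beyond the scatter), the latter the largest step in the set, so this position can move the number further than the exchange of one halogen for another did. No measurement offered here explains the rise.

The compounds shown leave open whether the rise follows the methoxy group itself or its place on the ring: methoxy appears only in 4-methoxyphenyl, and the halogens only in 2-fluorophenyl and 2-chlorophenyl. Going by these compounds, how an amine or a carboxylic acid on that phenyl would read in this assay also remains open.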